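A few compounds are considered here, and "the series" means these few. Any claim that something is new, unique, unknown or untested is made for them only; others in the source may bear on it.

Measured so far:
Compound 1 `Cc1c(O)ccc2c1[C@H](Cn1cc(-c3ccccn3)nn1)[C@@]13CC(=O)[C@@](C)(CC[C@@H]21)C3`: in a functional assay on SMMC-7721 cells (Homo sapiens) for cytotoxicity, read by MTT assay, with a stated time of 4 days (on this read-out lower numbers stand for stronger inhibition and higher numbers for weaker inhibition), compound 1 returns only the limit > 20000 nM.
Compound 2 `C=C1C(=O)[C@]23C[C@@]1(O)CC[C@H]2c1ccc(OS(=O)(=O)c2ccc(C)cc2)c(C)c1[C@@H]3Cn1cc(-c2ccc(F)cc2)nn1`: in this assay compound 2 gives 4280 nM.
Compound 3 `C=C1C[C@]23C[C@@]1(O)CC[C@H]2c1ccc(OS(=O)(=O)c2ccc(C)cc2)c(C)c1[C@@H]3Cn1cc(-c2ccc(C(F)(F)F)cc2)nn1`: in this assay compound 3 returns only the limit > 20000 nM.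

Within the data shown here, compound 2 stands as the only numeric value on record in this assay; the other two entries are limits, as captured by the limit of > 20000 nM in this assay, at which 2 of the 3 values shown sit. Compound 4 `C=C1C(=O)[C@]23C[C@@]1(O)CC[C@H]2c1ccc(OS(=O)(=O)c2ccc(C)cc2)c(C)c1[C@@H]3Cn1cc(-c2ccc(OC)cc2)nn1` differs from compound 2 by methoxy in place of fluoro on an aromatic carbon. Among the measured compounds shown here, no step between two measured compounds differing in a single place is available, so the size of this change cannot be read from the series itself. With compound 2 as the sole numeric anchor, the expectation is a step of a 1.5-fold higher number from compound 2 to compound 4 (0.18 log units; within the scatter), tending toward weaker inhibition or nothing beyond the scatter, with a real chance that only a limit is returned. Compound 4 is estimated at 6500 nM, between 2000 nM and 20000 nM.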

Compound 4, half-maximal inhibitory concentration: 1720 nM
Compound 4: middle estimate off by 3.8-fold (0.58 log units), on the high side; measured number below the stated range.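

In this assay, among these compounds, methoxy in place of fluoro gives the first readable step: a 2.5-fold lower number from compound 2 to compound 4 (0.40 log units; beyond the scatter). The aromatic carbon para to a large group therefore responds to substitution, and the 4-methoxyphenyl compound keeps a numeric value rather than falling to a limit. This change moves the number toward stronger inhibition, though only as a single modest step.

Going by these compounds, whether an amine or a carboxylic acid at this carbon would continue that direction remains open. Numeric anchors also remain few: the limit of > 20000 nM in this assay, at which 2 of the 4 values shown sit.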